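The source may hold more compounds than are shown below. What is called first, only, known or untested is meant among the compounds shown, and "the series" means these compounds.

In a functional assay on the whole organism for antagonist activity, with Mus musculus as the target (on this read-out lower numbers stand for an effect already at smaller amounts and higher numbers for an effect only at larger amounts of compound), compound 1 `CN(C(=O)CNC(=O)CN1CCCCC1)c1ccc(Cl)cc1C(=O)c1ccccc1Cl` gives 7.5 mg/kg, compound 2 `CCCCCC(=O)NCC(=O)N(C)c1ccc(Cl)cc1C(=O)c1ccccc1Cl` gives 1.9 mg/kg, and compound 3 `CC(NC(=O)CN)C(=O)N(C)c1ccc(Cl)cc1C(=O)c1ccccc1Cl` gives 0.47 mg/kg, the lowest of the three numbers and beyond the scatter from both others. Compound 4 `CCCCCCC(=O)NCC(=O)N(C)c1ccc(Cl)cc1C(=O)c1ccccc1Cl` has ((hexylcarbonyl)amino)methyl in place of 1-(((aminomethyl)carbonyl)amino)ethyl on a carbonyl carbon. The entering group closely resembles the ((pentylcarbonyl)amino)methyl of compound 2, so the most relevant measurement is a 4.0-fold lower number from compound 2 to compound 3 (0.61 log units; beyond the scatter), here run backwards. The other measured step, a 3.9-fold lower number from compound 1 to compound 2 (0.60 log units; beyond the scatter), is of similar modest size. In this assay, a modest move to a higher number is therefore expected, estimated as a 4.9-fold higher number from compound 3 to compound 4 (0.69 log units; beyond the scatter). For compound 4 the estimated value is 2.3 mg/kg, with an expected range from 0.9 mg/kg to 6 mg/kg.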

Compound 4, dose for half-maximal effect: 1.9 mg/kg
Beside the measured number, compound 4's estimate is 1.2-fold (0.08 log units) above it; the range from low to high includes it.
By their numbers in this assay, from the lowest: compound 3; then compounds 2 and 4 (each within the scatter of the next); then compound 1.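

Methyl in place of hydrogen on the saturated chain shows no change at the digits printed from compound 2 to compound 4 (within the scatter), so in this assay the pentyl and hexyl versions of this amide stand level. The gap to the group of compound 3 remains with a 4.0-fold higher number from compound 3 to compound 4 (0.61 log units; beyond the scatter), and the advantage over the piperidin-1-yl group holds with a 3.9-fold lower number from compound 1 to compound 4 (0.60 log units; beyond the scatter). No measurement here explains these steps. Still open, as far as these compounds go, is whether a butyl chain or an octyl chain would stay level with these two. Also open, from the compounds shown here alone, is whether a terminal amine on the hexyl chain would reach the number of compound 3.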